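Benzyl for methoxyphenyl on a triazine piperazine

The compounds below may be only part of what the source reports. "The series", "measured", "known", "first", "only" and "open" are said of these compounds alone.

Compound 2 `COc1ccc(N2CCN(c3nc(Nc4ccc(C#N)c(C(F)(F)F)c4)nc(Oc4ccnc5ccccc45)n3)CC2)cc1` gives only a limit in a functional assay on DU-145 cells (Homo sapiens) for cytotoxicity, read by sulforhodamine B assay, with a stated time of 48 h (a lower number here means a stronger inhibitor of growth, a higher number a weaker inhibitor of growth), namely > 100000 nM. Compound 1 `N#Cc1ccc(Nc2nc(Oc3ccnc4ccccc34)nc(N3CCN(C(c4ccccc4)c4ccc(Cl)cc4)CC3)n2)cc1C(F)(F)F` likewise reaches only the limit > 100000 nM in this assay. Both compounds sit at the limit of > 100000 nM in this assay, at which 2 of the 2 values shown sit, so compound 2 stands no apart from compound 1 on the numbers shown. Compound 3 `N#Cc1ccc(Nc2nc(Oc3ccnc4ccccc34)nc(N3CCN(Cc4ccccc4)CC3)n2)cc1C(F)(F)F` differs from compound 2 by benzyl in place of 4-methoxyphenyl on an amine nitrogen in a ring. Going by the values given here, no measured step exists to guide this change. Since both known compounds rest at the limit, the step in this assay is expected to stay within the scatter. Compound 3 is expected to give 100000 nM, in a range from 30000 nM to 300000 nM. The expected step is a number no higher from compound 2 to compound 3 (the limit leaves the size open).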

Compound 3, concentration for 50% growth inhibition: > 100000 nM
Compound 3 was reported as a limit (the forecaster's own chance of this, stated with the estimate: 80%); the middle value sits exactly at the limit.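

In this assay the steps from compound 1 and from compound 2 to compound 3 cannot be read, as all three compounds rest at a limit: the limit of > 100000 nM in this assay, at which 3 of the 3 values shown sit. The compounds shown leave open the actual growth-inhibiting concentration of each, and so whether benzyl and 4-methoxyphenyl differ at all.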